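The source may report more compounds than this note shows. Statements on the series, on what has been measured and on what is new or still open speak of the compounds shown alone.

Measured compounds:
compound 1 `CNc1nc(NCc2ccc(OC(F)(F)F)cc2)cc(-c2ccccn2)n1` — 13 nM
compound 2 `CNc1nc(NCc2ccc(Cl)cc2Cl)cc(-c2ccccn2)n1` — 0.8 nM
compound 3 `CNc1nc(NCc2ccc(Cl)cc2)cc(-c2ccccn2)n1` — 15 nM

In a functional assay on HEK293 cells for agonist activity at G-protein coupled receptor 39 (Homo sapiens), read by inositol phosphate accumulation (on this read-out higher numbers stand for an effect only at larger amounts of compound and lower numbers for an effect already at smaller amounts), compound 3 gives the highest number of the three; compound 1 sits within the scatter of it, compound 2 far below it. Compound 4 `CNc1nc(NCc2ccncc2)cc(-c2ccccn2)n1` differs from compound 3 by pyridin-4-yl in place of 4-chlorophenyl on a saturated chain carbon bound to a nitrogen on an aromatic ring. Within the data shown here, no measured step swaps a whole ring, so both known steps bear on it only loosely: a 1.2-fold higher number from compound 1 to compound 3 (0.06 log units; within the scatter) is within the scatter, whereas a 19-fold higher number from compound 2 to compound 3 (1.27 log units; beyond the scatter) is large. On these data alone, compound 4 gives up the remaining chloro, so a further rise in this assay is expected rather than a fall, though the pyridin-4-yl ring itself is untested. For compound 4 an estimate of 60 nM (range 15 nM to 300 nM) is expected, a step of a 4.0-fold higher number from compound 3 to compound 4 (0.60 log units; beyond the scatter) from compound 3.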

Compound 4, half-maximal effective concentration: 87 nM
Beside the measured number, compound 4's estimate is 1.5-fold (0.16 log units) below it, and the stated range covers the measured number.
By their numbers in this assay, from the lowest: compound 2; then compounds 1 and 3 (each within the scatter of the next); then compound 4.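

In this assay, among these compounds, the first whole-ring change at this place, pyridin-4-yl in place of 4-chlorophenyl, gives a 5.8-fold higher number from compound 3 to compound 4 (0.76 log units; beyond the scatter) and so raises the number beyond the scatter, while pyridin-4-yl in place of 2,4-dichlorophenyl gives a 110-fold higher number from compound 2 to compound 4 (2.04 log units; beyond the scatter) as a large step. A carbon-only ring is therefore not interchangeable here with a ring holding one hetero atom and one hydrogen-bond acceptor. Nothing available explains either step.

Open, on these data alone, is whether chloro on the pyridin-4-yl ring would restore lower numbers. Also open, as far as these compounds go, is how a piperidine ring or a longer chain would fare at this place.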